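A few compounds are considered here, and "the series" means these few. Any claim that something is new, unique, unknown or untested is made for them only; others in the source may bear on it.

Compound 1, `Cc1ccc(NC(=O)C(=O)NC(c2nc(C)c(CCO)s2)C2CCCCN2)cc1F`: in an ADME assay on TZM-b1 cells (Homo sapiens) for cytotoxicity, read by XTT assay, with a stated time of 3 days (a higher number here means that more compound is tolerated, a lower number that less compound is tolerated), compound 1 gives > 85000 nM, which is a limit of the assay, not a number.
Compound 2, `Cc1nc(C(NC(=O)C(=O)Nc2ccc(Cl)cc2)C2CCCCN2)sc1CO`: in this assay compound 2 gives > 22000 nM, also a limit.
Compound 3, `Cc1ccc(NC(=O)C(=O)NC(c2nc(C)c(CO)s2)C2CCCCN2)cc1F`: in this assay compound 3 gives > 88000 nM, again a limit.

Compound 1 therefore stands at a limit in this assay, and the two other values shown are limits as well, so no order among the three compounds can be read. Compound 4, `Cc1nc(C(NC(=O)C(=O)Nc2ccc(Cl)c(F)c2)C2CCCCN2)sc1CCO`, differs from compound 1 by chloro in place of methyl on an aromatic carbon. Within the data shown here, the measured steps a step that the two limits leave unreadable from compound 1 to compound 3 and a step that the two limits leave unreadable from compound 2 to compound 3 both run between limits and give no readable size; neither of them touches the exchange of methyl for chloro on the aromatic ring, so no step bears directly on the change to compound 4. Among the measured compounds shown here, the only guidance is that compound 1 sits at the limit of > 85000 nM in this assay, at which 1 of the 3 values shown sits, and that the other measured compounds likewise reach only limits, the limit of > 22000 nM in this assay, at which 1 of the 3 values shown sits, and (the limit of > 88000 nM in this assay, at which 1 of the 3 values shown sits). Compound 4 is therefore expected to be tolerated to a similar degree, with the step of a number no higher from compound 1 to compound 4 (the limit leaves the size open) expected to stay within the scatter. The estimate for compound 4 in this assay is 85000 nM, with a range from 30000 nM to 200000 nM, most likely again reported as a limit.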

Compound 4, half-maximal cytotoxic concentration: 61000 nM
Estimate against measurement, compound 4: 1.4-fold (0.14 log units) above; measured number inside the range.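

Among these compounds, compound 4 is the only one of the four compounds to give a number rather than a limit in this assay. Among the compounds shown here, the exchange of methyl for chloro, on an aromatic carbon ortho to a fluoro group and para to a large group, therefore gives the only step of readable size, whereas the earlier steps cannot be read: it is an at least 1.3-fold lower number from compound 1 to compound 4 (0.14 log units; that floor lies within the scatter). Compound 1 itself remains a limit, and its floor shows no change beyond the scatter at this position: the limit of > 85000 nM in this assay, at which 1 of the 4 values shown sits.

As far as these compounds go, the full size of this step stays open, since only its floor can be read. Also open, from the compounds shown here alone, is how a bromo or a methoxy group at this same place would compare, and whether chloro for methyl gives the same result with a hydroxymethyl chain on the core.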